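The source may report more compounds than this note shows. Statements on the series, on what has been measured and on what is new or still open speak of the compounds shown alone.

Compound 3 `CCCCCCNc1nccnc1C(=O)NCc1ccccc1` and compound 4 `CCCCCNc1nccnc1C(=O)NCc1ccccc1` share one core and differ only in the length of the saturated chain attached to a nitrogen on an aromatic ring. They belong to a small set that also holds compound 1 `CCCCNc1nccnc1C(=O)NCc1ccccc1` and compound 2 `O=C(NCc1ccccc1)c1nccnc1Cl`. The measurement is an ADME assay on Vero cells (Chlorocebus sabaeus) for cytotoxicity, read by microscopy, with a stated time of 6 days; a higher number here means that more compound is tolerated, a lower number that less compound is tolerated. In this assay compound 3 reaches only a limit of the assay, > 100000 nM. Compound 1 likewise reaches only a limit in this assay, > 100000 nM. For compound 2 the entry in this assay reads "not determined" (no result reported). Going by the values given here, the single step between measured compounds is a step that the two limits leave unreadable from compound 1 to compound 3; its size cannot be read because both of its ends sit at the limit of > 100000 nM in this assay, at which 2 of the 3 values shown sit. Compound 3 thus stands at that limit, alongside compound 1, with compound 2 offering no number to compare. The change to compound 4 is hydrogen in place of methyl on a saturated chain carbon, five bonds along the chain from a nitrogen on an aromatic ring. Among the compounds with values here, no measured step speaks to this change in a readable way, so no shift beyond the scatter is expected, and the step from compound 3 to compound 4 is estimated at a step that the limit leaves unreadable from compound 3 to compound 4. Compound 4 is expected to give 150000 nM in this assay, most likely again only as a limit, within 60000 nM to 400000 nM.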

Compound 4, minimum cytotoxic concentration: > 100000 nM
Compound 4 ended at the assay's limit; the forecaster's own chance of this, stated with the estimate: 85%; the middle value is on the limit's open side.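

No step among compound 1, compound 3 and compound 4 can be read in this assay, because each result is only a limit of the assay and not a number: the limit of > 100000 nM in this assay, at which 3 of the 4 values shown sit.

The compounds shown leave open whether the length of the saturated chain changes how much compound the cells tolerate.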